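The source may hold more compounds than are shown below. What is called first, only, known or untested is meant among the compounds shown, and "the series" means these compounds.

Measured so far:
compound 1 `OC[C@]1(c2cccc(F)c2)NC[C@H](O)[C@H]1O`: 0%
compound 2 `OC[C@@]1(c2cccc(F)c2)NC[C@@H](O)[C@@H]1O`: 0%

In an assay on isolated protein for inhibition of tissue alpha-L-fucosidase (Bos taurus), tested at 1000 uM (a higher number here means more inhibition at the concentration tested (going by the name of the read-out), a lower number less inhibition), compound 1 gives 0%, and compound 2 gives 0%. For the measured compounds named here, the only measured step, no change at the digits printed from compound 1 to compound 2 (within the scatter), lies within the scatter, consistent with the fact that compounds 1 and 2 differ only in the configuration as drawn. Compound 2 thus stands level with compound 1, at no inhibition.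

Compound 3 `COc1cccc([C@]2(CO)NC[C@@H](O)[C@@H]2O)c1` differs from compound 2 by methoxy in place of fluoro on an aromatic carbon. No measured step touches the aromatic substituent, so nothing shown speaks directly to this change; the one step available, no change at the digits printed from compound 1 to compound 2 (within the scatter), was flat. A step of a number 3 percentage points higher from compound 2 to compound 3 (within the scatter) is therefore expected, none beyond the scatter. Compound 3 is estimated at 3%, ranging from 0% to 15%.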

Compound 3, a percentage reported as inhibition, at one concentration (the size of the read-out at that concentration, not a potency): 0%
The estimate for compound 3 lay 3 percentage points above the measured number; measured number inside the range.
By their numbers in this assay, from the lowest: compounds 1, 2 and 3 (each within the scatter of the next).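

In this assay, the substituent on the aromatic ring, which the earlier pair left untouched, now has a step of its own, with no change at the digits printed from compound 2 to compound 3 (within the scatter). Methoxy in place of fluoro at this aromatic carbon therefore does not separate compound 3 from compound 2 in this read-out, and both compounds remain without detectable inhibition. Nothing available accounts for this flat step.

From the compounds shown here alone, whether an amine or a carboxylic acid on this aromatic carbon would give any inhibition remains open. So does the effect of a longer chain in place of the methoxy group.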